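A fluorinated anilino group replaces pyrrolidine on the shared core

The source may report more compounds than this note shows. Statements on the series, on what has been measured and on what is new or still open speak of the compounds shown alone.

Of the compounds shown here, two on a shared core have been tested in a functional assay on ECa-109 cells for inhibition, with ECa-109 cell line (Homo sapiens) as the target, read by sulforhodamine B assay; on this read-out lower numbers stand for stronger inhibition and higher numbers for weaker inhibition. Compound 1 `CCCc1ccc(NC2=CC(=O)c3nc4n(c3C2=O)[C@H]2OC[C@@H](O)[C@H]2OC4)cc1` gives only a limit of the assay in this assay, namely > 4000 nM. Compound 2 `O=C1C(N2CCCC2)=CC(=O)c2c1nc1n2[C@H]2OC[C@@H](O)[C@H]2OC1` likewise gives only a limit in this assay, > 16000 nM. For the measured compounds named here, compound 2 thus stands at the limit of > 16000 nM in this assay, at which 1 of the 2 values shown sits, while the other measured value stands at the limit of > 4000 nM in this assay, at which 1 of the 2 values shown sits; no numbered value exists on this core, and no step between measured compounds can be sized.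

Compound 3 `O=C1C(Nc2cccc(F)c2)=CC(=O)c2c1nc1n2[C@H]2OC[C@@H](O)[C@H]2OC1` differs from compound 2 in one place: (3-fluorophenyl)amino in place of pyrrolidin-1-yl on a double-bonded ring carbon. Both measured values are limits, so the data give no direction for this change, and the step in this assay is expected to be an at least 2.0-fold lower number from compound 2 to compound 3 (0.30 log units; that floor lies within the scatter), stated with little confidence. Compound 3 is therefore expected to show about 8000 nM in this assay, within 2000 nM to 40000 nM, and another limit rather than a number is quite possible.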

Compound 3, half-maximal inhibitory concentration: 2370 nM
The estimate for compound 3 lay 3.4-fold (0.53 log units) above the measured number; low and high end bracket the measured number.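

In this assay compound 3 gives 2370 nM, the first number rather than a limit on the shared core. This shows that the double-bonded ring carbon tolerates a change that moves the read-out, as (3-fluorophenyl)amino in place of pyrrolidin-1-yl gives an at least 6.7-fold lower number from compound 2 to compound 3 (0.82 log units; beyond the scatter). Compound 2 is only a limit of the assay, so the full size of this step stays unknown: the limit of > 16000 nM in this assay, at which 1 of the 3 values shown sits.

The change replaces the ring of pyrrolidin-1-yl with an aromatic ring, and also brings in a fluorine and a hydrogen-bond donor, and the compounds shown do not separate these parts. Plain phenylamino or a 3-chlorophenylamino group at the same carbon would be needed to show whether the fluorine matters.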